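The source may hold more compounds than are shown below. What is called first, only, known or untested is meant among the compounds shown, and "the series" means these compounds.

Compound 1, `CNc1cc(Oc2ccc(NC(=O)Nc3cccc(C(F)F)c3)cc2)ncn1`, gives 100 nM.
Compound 2, `O=C(Nc1ccc(Oc2ccncn2)cc1)Nc1cccc(C(F)(F)F)c1`, gives 160 nM.
Compound 3, `CNc1cc(Oc2c(C)cc(NC(=O)Nc3cccc(C(F)(F)F)c3)cc2C)ncn1`, gives 25 nM.

These three were tested in an assay on isolated protein for inhibition of serine/threonine-protein kinase TNNI3K (Homo sapiens); on this read-out lower numbers stand for stronger inhibition and higher numbers for weaker inhibition. Compound 2 has the highest of the three numbers; its gap to compound 1 lies within the usual scatter, while compound 3 shows a clearly lower number, beyond the scatter. Compound 4, `CC(=O)Nc1cc(Oc2ccc(NC(=O)Nc3cccc(C(F)(F)F)c3)cc2)ncn1`, has not yet been measured. It differs from compound 2 in one place: acetamido in place of hydrogen on an aromatic carbon. A small step is expected here, a 1.5-fold lower number from compound 2 to compound 4 (0.16 log units; within the scatter), since compound 1 gives 100 nM and thus shows that a methylamino group in that ring leaves the number within the scatter of compound 2. Compound 4 is expected to give 110 nM in this assay, within a range from 35 nM to 350 nM.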

Compound 4, half-maximal inhibitory concentration: 20 nM
Compound 4: middle estimate off by 5.5-fold (0.74 log units), on the high side; measured number outside the range, below it.
By their numbers in this assay, from the lowest: compounds 4 and 3 (each within the scatter of the next); then compounds 1 and 2 (each within the scatter of the next).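

Among these compounds, putting acetamido on the aromatic carbon next to the ring nitrogen gives in this assay an 8.0-fold lower number from compound 2 to compound 4 (0.90 log units; beyond the scatter) and this is the first single-place comparison at this position. It shows that this carbon is not indifferent to its substituent, and that a group of 4 heavy atoms placed there goes with stronger inhibition rather than a loss. Nothing measured here explains the gain.

Still open, as far as these compounds go, is whether a plain amino group or a longer chain such as propanamido at this carbon would give a similar number.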